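A few compounds are considered here, and "the series" means these few. Any claim that something is new, unique, unknown or untested is made for them only; others in the source may bear on it.

Measured compounds:
compound 1 `COC(=O)N1C[C@@H](C)N(c2ncc3[nH]nc(-c4ccc(N5CCN(C)CC5)cc4)c3n2)[C@@H](C)C1`: 0.98 nM
compound 2 `CC(C)C(=O)N1C[C@@H](C)N(c2ncc3[nH]nc(-c4ccc(N5CCN[C@H](C)C5)nc4)c3n2)[C@@H](C)C1`: 8 nM
compound 3 `C[C@@H]1CN(c2ccc(-c3n[nH]c4cnc(N5[C@H](C)COC[C@@H]5C)nc34)cn2)CCN1`: 23 nM

All three were tested in an assay on Sf9 cells for inhibition of activin receptor type-1 (Homo sapiens), read by HTRF, with a stated time of 3 h, in the presence of a further agent that is not named here; on this read-out lower numbers stand for stronger inhibition and higher numbers for weaker inhibition. On these numbers compound 2 sits second highest of the three. Its nearest neighbour is compound 3, whose value of 23 nM is higher than that of compound 2 by more than the usual scatter. The lowest number belongs to compound 1, which gives 0.98 nM in this assay, again a gap beyond the scatter.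

The next compound is compound 4 `CCOC(=O)N1C[C@@H](C)N(c2ncc3[nH]nc(-c4ccc(N5CCN[C@H](C)C5)nc4)c3n2)[C@@H](C)C1`, which has not been measured. It differs from compound 2 in one place: ethoxy in place of isopropyl on a carbonyl carbon

Going by the values given here, no pair of measured compounds differs in just this one place, so there is no direct guide to the size of this step. Compound 1 carries a related ethoxycarbonyl-like group cut down by one carbon and gives the lowest number, but it also differs from compound 2 elsewhere, so its value cannot be credited to that group alone. The expectation is a small step in this assay, toward a lower number, of a size that may not clear the scatter: the step from compound 2 to compound 4 is estimated as a 2.0-fold lower number from compound 2 to compound 4 (0.30 log units; within the scatter). Compound 4 is therefore expected to give about 4 nM, within a range from 1.5 nM to 12 nM.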

Compound 4, half-maximal inhibitory concentration: 4.9 nM
Beside the measured number, compound 4's estimate is 1.2-fold (0.09 log units) below it, within the range that was stated.
By their numbers in this assay, from the lowest: compound 1; then compounds 4 and 2 (each within the scatter of the next); then compound 3.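

In this assay, going by these compounds alone, the step of a 1.6-fold lower number from compound 2 to compound 4 (0.21 log units; within the scatter) gives the first direct reading at this place, the carbonyl carbon attached to an amide-type nitrogen in a ring. Ethoxy brings an oxygen and a hydrogen-bond acceptor that isopropyl lacks, yet with the rest of the molecule unchanged, this exchange does not move the number beyond the usual scatter, so the assay does not separate the two groups here. Nothing available here gives a reason for this result, and no separate measurement bears on it.

This single pair cannot show whether the same exchange would give a similarly small step if other parts of the molecule were different, and it describes only these two groups at this place. It also leaves open whether a longer chain such as butoxy, or an amine such as dimethylamino, on the same carbonyl carbon would change the number by more than the scatter.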